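Polar side chain added where earlier groups raised tolerance

The source may hold more compounds than are shown below. What is called first, only, known or untested is meant among the compounds shown, and "the series" means these compounds.

Compound 1 `O=c1n(Cc2cn3ccc(Cl)cc3n2)c2cnccc2n1C1CC1` is the only one of the three measured compounds with a number in an ADME assay on HEp-2 cells (Homo sapiens) for cytotoxicity, read by CCK-8 assay, with a stated time of 6 days; a lower number here means that less compound is tolerated, a higher number that more compound is tolerated: in this assay compound 1 gives 22300 nM. Compound 2 `NC(=O)CCc1c(Cn2c(=O)n(C3CC3)c3ccncc32)nc2cc(Cl)ccn12` returns only a limit of the assay, > 100000 nM. Compound 3 `O=c1n(Cc2nc3cc(Cl)ccn3c2NC2CCCCC2)c2cnccc2n1C1CC1` likewise returns a limit, > 100000 nM. What stands out is the limit of > 100000 nM in this assay, at which 2 of the 3 values shown sit. The unmeasured compound 4 `O=c1n(Cc2nc3cc(Cl)ccn3c2CNCCO)c2cnccc2n1C1CC1` differs from compound 1 in one place: ((2-hydroxyethyl)amino)methyl in place of hydrogen on an aromatic carbon. Going by the values given here, two measured steps bear on this change, both made at the same aromatic carbon: an at least 4.4-fold higher number from compound 1 to compound 2 (0.65 log units; beyond the scatter) and an at least 4.4-fold higher number from compound 1 to compound 3 (0.65 log units; beyond the scatter). Between compound 2 and compound 3 there is a step that the two limits leave unreadable from compound 2 to compound 3. Because an at least 4.4-fold higher number from compound 1 to compound 2 (0.65 log units; beyond the scatter) and an at least 4.4-fold higher number from compound 1 to compound 3 (0.65 log units; beyond the scatter) were each at least modest rises, the ((2-hydroxyethyl)amino)methyl group in compound 4 is expected to give a comparable step of a 4.5-fold higher number from compound 1 to compound 4 (0.65 log units; beyond the scatter). Compound 4 is therefore estimated at about 100000 nM in this assay, within 40000 nM to 300000 nM, with a fair chance that only a limit is reported.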

Compound 4, half-maximal cytotoxic concentration: > 100000 nM
Compound 4 was reported as a limit; the forecaster's own chance of this, stated with the estimate: 60%; the middle value lies on the limit itself.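

With ((2-hydroxyethyl)amino)methyl in place of hydrogen, this assay shows an at least 4.4-fold higher number from compound 1 to compound 4 (0.65 log units; beyond the scatter), so the rise at this aromatic carbon now holds for a third group, an open chain with no ring, and none of the listed compounds goes against it. Compound 4 returns a limit of the assay and not a number, as do compound 2 and compound 3, and the steps among these three cannot be read. The data at this position therefore show a shared ceiling and no order among the three groups: the limit of > 100000 nM in this assay, at which 3 of the 4 values shown sit.

The compounds shown leave open whether a methyl group or a carboxylic acid on this carbon would also raise the number from compound 1. They also leave open how far compound 2, compound 3 and compound 4 lie from one another.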